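A Methyl in Place of Fluorine on Compound 2

This account rests on a few compounds, and the source may have more. Where it says the series, first, only, none or still open, it means among the compounds named here.

Measured so far:
- compound 1, `CCCCCc1ccc(-c2cn(C/C=C3\OC(=O)C(OCc4ccccc4)=C3OCc3ccccc3)nn2)cc1`: > 100000 nM
- compound 2, `O=C1O[C@H]([C@@H](O)Cn2cc(CNS(=O)(=O)c3ccc(F)cc3)nn2)C(OCc2ccccc2)=C1OCc1ccccc1`: 18300 nM
- compound 3, `COc1ccccc1-c1cn(C/C=C2\OC(=O)C(OCc3ccccc3)=C2OCc2ccccc2)nn1`: > 100000 nM

Of the compounds shown here, three have been tested in a functional assay on HepG2 cells (Homo sapiens) for antiproliferative activity, read by MTT assay, with a stated time of 72 h; a lower number here means a stronger inhibitor, a higher number a weaker inhibitor. For compound 1 the result is only a limit of the assay, > 100000 nM. For compound 3 the result is likewise only a limit, > 100000 nM. The change from compound 1 to compound 3 is therefore a step that the two limits leave unreadable from compound 1 to compound 3, since both ends sit at the limit of > 100000 nM in this assay, at which 2 of the 3 values shown sit. Going by the values given here, compound 2 is the only compound with an actual number, 18300 nM, so within this small set it stands as the one measurable inhibitor.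

The next compound, compound 4, `Cc1ccc(S(=O)(=O)NCc2cn(C[C@H](O)[C@H]3OC(=O)C(OCc4ccccc4)=C3OCc3ccccc3)nn2)cc1`, differs from compound 2 in one place: methyl in place of fluoro on an aromatic carbon. Among the compounds with values here, no measured step among the three compounds involves this kind of change, and the single readable value gives no guide to the size of the effect. Without any evidence pointing in either direction, the expectation is a step from compound 2 to compound 4 of about a 1.0-fold lower number from compound 2 to compound 4 (0.01 log units; within the scatter), that is, no change beyond the usual scatter. Compound 4 is therefore expected to give about 18000 nM in this assay, with a likely range from 6000 nM to 55000 nM.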

Compound 4, half-maximal inhibitory concentration: 24900 nM
Compound 4: the middle estimate sits 1.4-fold (0.14 log units) below what was measured; measured number inside the range.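

In this assay, putting methyl in place of fluoro on the aromatic carbon para to a large group gives a 1.4-fold higher number from compound 2 to compound 4 (0.13 log units; within the scatter). Going by these compounds alone, this is the first step in the set that can be read, as the earlier step joins two values that are both limits of the assay, so it gives the first measured view of a change on this ring: turning 4-fluorophenyl into 4-methylphenyl leaves the result within the usual scatter. A single pair cannot show whether this carbon accepts other groups equally well, and nothing measured here gives a reason for the outcome at this position.

What the compounds shown leave open is how far this tolerance extends, since fluoro and methyl are the only two groups compared on this carbon, and an amine, a carboxylic acid or a longer chain such as propyl might give a different result. Also open, from the compounds shown here alone, is whether methyl in place of fluoro would give a similarly small step at another carbon of the same ring, or on a compound with a different side chain attached to the shared core.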